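From phenyl to 4-methylbenzyl at the assay limit

This account rests on a few compounds, and the source may have more. Where it says the series, first, only, none or still open, it means among the compounds named here.

In a functional assay on Jurkat cells (Homo sapiens) for inhibition, read by CCK-8 assay, with a stated time of 48 h (a lower number here means a stronger inhibitor of growth, a higher number a weaker inhibitor of growth), compound 3 `CN1CCN(c2ccc(Nc3ncc(Cl)c(Nc4ccccc4)n3)nc2)CC1` gives only a limit, > 100000 nM. Compound 1 `Cc1ccc(Nc2ncc(Cl)c(Nc3ccccc3C)n2)cc1` also gives only a limit, > 100000 nM. Both stand at the limit of > 100000 nM in this assay, at which 2 of the 3 values shown sit. Compound 2 `Cc1ccccc1Nc1nc(Nc2ccc(N3CCCN(C)CC3)cc2)ncc1Cl` reaches a true number, 11300 nM. Among the compounds with values here, the one measured step, an at least 8.8-fold lower number from compound 1 to compound 2 (0.94 log units; beyond the scatter), puts 4-methyl-1,4-diazepan-1-yl in place of methyl on an aromatic carbon. Compound 4 `Cc1ccc(CNc2nc(Nc3ccc(N4CCN(C)CC4)cn3)ncc2Cl)cc1` differs from compound 3 at another place: 4-methylbenzyl in place of phenyl on a nitrogen on an aromatic ring. The measured step is a different change, so it bears only loosely, and a step no larger than it is expected in this assay, towards a lower number. The expected step is an at least 2.5-fold lower number from compound 3 to compound 4 (0.39 log units; beyond the scatter). Compound 4 is estimated at 40000 nM, within 8000 nM to 100000 nM.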

Compound 4, concentration for 50% growth inhibition: 12700 nM
Compound 4: middle estimate off by 3.1-fold (0.50 log units), on the high side, within the range that was stated.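

In this assay, 4-methylbenzyl in place of phenyl on a nitrogen on an aromatic ring gives an at least 7.8-fold lower number from compound 3 to compound 4 (0.89 log units; beyond the scatter). Within the data shown here, the earlier step showed a change at another place, so this is the first sign that this position can also move the read-out. From the compounds shown here alone, the true size of the step remains unknown, since compound 3 stands at a limit of the assay: the limit of > 100000 nM in this assay, at which 2 of the 4 values shown sit. Going by these compounds, it remains open whether the methyl or the longer link to the ring carries this step. A plain benzyl, a phenethyl chain or a carboxylic acid on the benzyl ring could separate these.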